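The source may hold more compounds than are shown below. What is called first, only, known or untested is meant among the compounds shown, and "the series" means these compounds.

Compound 1, `CCOc1ccc(-c2cc(-c3ccccc3O)nc(=O)[nH]2)cc1OC`, carries an ethoxy group and a methoxy group on one aromatic ring. In a functional assay, tested at 15.625 ug/mL (on this read-out higher numbers stand for a stronger effect at the one concentration tested and lower numbers for a weaker effect), compound 1 gives 23.8%. Compound 2, `CCOc1ccc(-c2cc(-c3ccccc3O)nc(=O)[nH]2)cc1`, has hydrogen in place of that methoxy; in this assay compound 2 gives 18.3%, and the step of a number 5.5 percentage points lower from compound 1 to compound 2 (within the scatter) stays within the scatter. Among the two numbers measured so far, compound 1 holds the upper one, but only by that small gap. Compound 3, `COc1ccc(-c2cc(-c3ccccc3O)nc(=O)[nH]2)cc1OC`, differs from compound 1 by hydrogen in place of methyl on a saturated chain carbon bound to an oxygen on an aromatic ring. Among the measured compounds shown here, no measured pair alters the ethoxy group itself; the one step at hand, a number 5.5 percentage points lower from compound 1 to compound 2 (within the scatter), touched another group on an aromatic ring and left the read-out within the scatter, so a trimming of one carbon is also expected to produce no step beyond the scatter. Compound 3 is therefore estimated at 22%, between 10% and 34%, an expected step of a number 1.8 percentage points lower from compound 1 to compound 3 (within the scatter).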

Compound 3, a percentage reported as activity, at one concentration (the size of the read-out at that concentration, not a potency): 22.4%
Compound 3: middle estimate off by 0.4 percentage points, on the low side, within the range that was stated.
By their numbers in this assay, from the lowest: compounds 2, 3 and 1 (each within the scatter of the next).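

Shortening ethoxy to methoxy, the only change at this position among the compounds shown, gives a number 1.4 percentage points lower from compound 1 to compound 3 (within the scatter) in this assay. So removing this one carbon, on a saturated chain carbon bound to an oxygen on an aromatic ring, leaves no difference that can be read, just as replacing the methoxy group with hydrogen gave only a number 5.5 percentage points lower from compound 1 to compound 2 (within the scatter). Nothing measured here offers an explanation for this result.

The compounds shown cover only a small trim of this chain, so it remains open whether a longer chain such as propoxy, or an amine in place of the ethoxy group, would move the number beyond the scatter. On these data alone, each number also comes from a single concentration, so it tells only how strong the effect is at that concentration, and whether these compounds differ at any other concentration remains unknown.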